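The source may hold more compounds than are shown below. What is called first, only, known or untested is meant among the compounds shown, and "the series" means these compounds.

Compound 1 `O=C(CN1CCN(c2ccc(Cl)cc2)CC1)N1CCN(c2nnc(-c3ccccc3)c(-c3ccccc3)n2)CC1` gives 113000 nM in an ADME assay on NIH3T3 cells (Mus musculus) for cytotoxicity, read by MTT assay, with a stated time of 24 h; a higher number here means a weaker inhibitor, a lower number a stronger inhibitor.
Compound 2 `O=C(CN1CCN(c2ccc([N+](=O)[O-])cc2)CC1)N1CCN(c2nnc(-c3ccccc3)c(-c3ccccc3)n2)CC1` gives only a limit of the assay in this assay, > 886000 nM.
Compound 3 `O=C(CN1CCN(c2ccc(Cl)cc2)CC1)N1CCN(c2nnc(-c3ccc(Cl)cc3)c(-c3ccc(Cl)cc3)n2)CC1` likewise gives only a limit of the assay in this assay, > 803000 nM.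

Compound 2 differs from compound 1 in one place: nitro in place of chloro on an aromatic carbon. That change made an at least 7.8-fold higher number from compound 1 to compound 2 (0.89 log units; beyond the scatter), with the measured number stopping at the limit of > 886000 nM in this assay, at which 1 of the 3 values shown sits. Compound 4 `O=C(CN1CCN(c2ccc([N+](=O)[O-])cc2)CC1)N1CCN(c2nnc(-c3ccc(Cl)cc3)c(-c3ccc(Cl)cc3)n2)CC1` has not yet been tested in this assay. It differs from compound 3 by the same change, made at the same place: nitro in place of chloro on an aromatic carbon. How the core of compound 3 differs from the core of compound 1 is not broken down here. Compound 3 already sits at the limit of > 803000 nM in this assay, at which 1 of the 3 values shown sits, so the step from compound 3 to compound 4 is expected to be a step that the limit leaves unreadable from compound 3 to compound 4, most likely ending in another limit rather than a number. Compound 4 is therefore estimated at 1200000 nM, somewhere between 500000 nM and 3000000 nM.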

Compound 4, half-maximal inhibitory concentration: > 789000 nM
Compound 4: only a limit was reported; the forecaster's own chance of this, stated with the estimate: 85%; the middle value does not contradict the limit.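

Compound 3 and compound 4 each give only a limit of the assay in this assay, and the step between them cannot be read. The compounds shown leave open whether nitro in place of chloro shifts the number on the core of compound 3 as it does on the core of compound 1.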